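Swapping Fluoro for Nitro on the Aromatic Ring

The compounds below may be only part of what the source reports. "The series", "measured", "known", "first", "only" and "open" are said of these compounds alone.

Three compounds share one core and differ only in the group on a single aromatic carbon. Compound 1 `CC1=C(/C=C/C(=O)/C=C/c2ccccc2)C(C)(C)CCC1O` carries hydrogen there, and in a functional assay on PC-3 cells (Homo sapiens) for cytotoxicity, read by MTT assay, with a stated time of 72 h (on this read-out lower numbers stand for stronger inhibition and higher numbers for weaker inhibition), compound 1 gives 15500 nM. Compound 2 `CC1=C(/C=C/C(=O)/C=C/c2ccc(C(F)(F)F)cc2)C(C)(C)CCC1O`, with trifluoromethyl in that place, gives 10200 nM in this assay, and compound 3 `CC1=C(/C=C/C(=O)/C=C/c2ccc(F)cc2)C(C)(C)CCC1O`, with fluoro, gives 6200 nM. Going by the values given here, compound 3 has the lowest of the three numbers, yet only one step sets it apart beyond the scatter, a 2.5-fold lower number from compound 1 to compound 3 (0.40 log units; beyond the scatter); the steps of a 1.5-fold lower number from compound 1 to compound 2 (0.18 log units; within the scatter) and a 1.6-fold lower number from compound 2 to compound 3 (0.22 log units; within the scatter) both stay within it.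

Compound 4 `CC1=C(/C=C/C(=O)/C=C/c2ccc([N+](=O)[O-])cc2)C(C)(C)CCC1O` extends the series: nitro in place of fluoro on an aromatic carbon. Among the compounds with values here, no measured step involves nitro. Within the data shown here, the steps that bear on it are the two changes at this same carbon, a 1.5-fold lower number from compound 1 to compound 2 (0.18 log units; within the scatter) and a 2.5-fold lower number from compound 1 to compound 3 (0.40 log units; beyond the scatter), and the swap a 1.6-fold lower number from compound 2 to compound 3 (0.22 log units; within the scatter). Because a 1.5-fold lower number from compound 1 to compound 2 (0.18 log units; within the scatter) stayed within the scatter and a 2.5-fold lower number from compound 1 to compound 3 (0.40 log units; beyond the scatter) was only modest, the expected step of a 1.2-fold lower number from compound 3 to compound 4 (0.09 log units; within the scatter) is small and could fall in either direction. Compound 4 is therefore estimated at 5000 nM in this assay, with a range from 2000 nM to 15000 nM.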

Compound 4, half-maximal inhibitory concentration: 15000 nM
Compound 4: the middle estimate sits 3.0-fold (0.48 log units) below what was measured; low and high end bracket the measured number.
By their numbers in this assay, from the lowest: compounds 3, 2, 4 and 1 (each within the scatter of the next, the first and the last beyond it).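

Going by these compounds alone, replacing fluoro with nitro gives a 2.4-fold higher number from compound 3 to compound 4 (0.38 log units; beyond the scatter) in this assay, so a change at this aromatic carbon can also move the number toward weaker inhibition, whereas the earlier steps from hydrogen all ran toward lower numbers, even if only one of them lay beyond the scatter. Measured against the hydrogen compound, nitro gives a 1.0-fold lower number from compound 1 to compound 4 (0.01 log units; within the scatter) and so cannot be told apart from having no added group at this carbon, which means that adding a group here does not by itself bring a gain. Against trifluoromethyl, nitro gives a 1.5-fold higher number from compound 2 to compound 4 (0.17 log units; within the scatter) and again cannot be separated, leaving compound 3 as the only compound here that stands clear of any other, and then only of compound 1 and compound 4, not of compound 2.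

The compounds shown leave open whether an amine, a methoxy group or chloro at this carbon would side with fluoro or with nitro, and whether fluoro would keep its edge on another carbon of the ring. No measurement given here accounts for the gap between fluoro and nitro.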